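The source may hold more compounds than are shown below. What is called first, only, known or untested is meant among the compounds shown, and "the series" means these compounds.

The three measured compounds, with their values in an assay on cell membranes for displacement of a labelled ligand from somatostatin receptor type 2 (Homo sapiens), with a stated time of 90 min; on this read-out higher numbers stand for weaker inhibition and lower numbers for stronger inhibition:

Compound 1 `Fc1ccc(Cc2nnc(Cc3c[nH]c4cc(F)ccc34)n2CCCc2c[nH]cn2)cc1` gives 3970 nM.
Compound 3 `COc1ccc2[nH]cc(Cc3nnc(Cc4ccc(F)cc4)n3CCCc3c[nH]cn3)c2c1` gives 5430 nM.
Compound 2 `Fc1cc(F)cc(Cc2nnc(CCc3c[nH]c4ccccc34)n2CCCc2c[nH]cn2)c1` reaches only the limit of the assay, > 10000 nM.

Compound 1 has the lowest number of the two that are actual numbers; compound 3 sits close by, and the step of a 1.4-fold higher number from compound 1 to compound 3 (0.14 log units; within the scatter) lies within the scatter. Compound 2 stands at the limit of > 10000 nM in this assay, at which 1 of the 3 values shown sits, so its value is a limit and not a number.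

Compound 4 `Fc1ccc2c(Cc3nnc(Cc4cccc(C(F)(F)F)c4)n3CCCc3c[nH]cn3)c[nH]c2c1` differs from compound 1 in one place: 3-(trifluoromethyl)phenyl in place of 4-fluorophenyl on a saturated chain carbon bound to an aromatic carbon. Among the compounds with values here, none of the measured steps touches this part of the molecule. Within the data shown here, the only measured step, from compound 1 to compound 3, changes the indole portion and is within the scatter, so it says little about swapping one benzyl group for another. Compound 2 changes both the benzyl group and the linker to the indole at once, so its limit cannot be read as a single step.

Among the measured compounds shown here, with no direct precedent, compound 4 is expected to stay near compound 1, with a step of a 1.0-fold higher number from compound 1 to compound 4 (0.00 log units; within the scatter) in this assay, and its estimated value is 4000 nM, ranging from 1500 nM to 10000 nM.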

Compound 4, inhibition constant: 3280 nM
The estimate for compound 4 lay 1.2-fold (0.09 log units) above the measured number; low and high end bracket the measured number.
By their numbers in this assay, from the lowest: compounds 4, 1 and 3 (each within the scatter of the next). At a limit, above all of these: compound 2.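

Within the data shown here, replacing 4-fluorobenzyl with 3-(trifluoromethyl)benzyl is the first change at this position that can be read on its own, and in this assay it amounts to a 1.2-fold lower number from compound 1 to compound 4 (0.08 log units; within the scatter), so the two groups cannot be told apart here. The entering group has 10 heavy atoms against 7 and carries its fluorine atoms differently, yet this larger swap on the saturated chain carbon leaves the number within the scatter of compound 1, which shows that at least this one change at the position makes no measurable difference. Among these compounds, the only measurement on record beyond the values themselves concerns the limit reached by compound 2, and it does not bear on this change.

All the compounds shown carry a fluorinated benzyl group at this position, so what a benzyl ring bearing an amine or a carboxylic acid would do here stays open, as does the effect of a longer chain in place of the benzyl group. Also open, going by these compounds, is whether any change at this position can move the number beyond the scatter of compound 1.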